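The compounds below may be only part of what the source reports. "The series", "measured", "known", "first", "only" and "open" are said of these compounds alone.

Working notes on the series, read in a functional assay on DU-145 cells (Homo sapiens) for inhibition, read by trypan blue exclusion, with a stated time of 72 h; a higher number here means a weaker inhibitor, a lower number a stronger inhibitor. Compound 1 (`COC(=O)Cn1c(=O)c(S(=O)(=O)c2ccc(F)cc2F)cc2cnc(Nc3ccc4[nH]ccc4c3)nc21`) gives 10000 nM, and compound 2 (`Cn1c(=O)c(S(=O)(=O)c2ccc(Cl)cc2Cl)cc2cnc(Nc3ccc4[nH]ccc4c3)nc21`) gives 1000 nM. Compound 3 (`Cn1c(=O)c(S(=O)(=O)c2ccc(F)cc2F)cc2cnc(Nc3ccc4sccc4c3)nc21`) gives 500 nM. That value lies within the scatter of compound 2, while compound 1 stands beyond the scatter on the higher side. For the measured compounds named here, these three compounds differ in more than one place, so no measured pair isolates a single change.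

Compound 4 (`Cn1c(=O)c(S(=O)(=O)c2ccc(F)cc2F)cc2cnc(Nc3ccc4cccc(O)c4n3)nc21`) carries 8-hydroxyquinolin-2-yl in place of 1-benzothiophen-5-yl on a nitrogen on an aromatic ring. The series offers no direct measure of this exchange. The only frame is the span of numbers from compound 3 at 500 nM to compound 1 at 10000 nM. Within that span, a step beyond the scatter towards a higher number, meaning weaker inhibition, is expected, though no step beyond the scatter remains possible. The estimated step is a 4.0-fold higher number from compound 3 to compound 4 (0.60 log units; beyond the scatter). Compound 4 is expected at 2000 nM, with an estimated range from 400 nM to 10000 nM.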

Compound 4, half-maximal inhibitory concentration: 5000 nM
Beside the measured number, compound 4's estimate is 2.5-fold (0.40 log units) below it; the measured number falls inside the stated range.
By their numbers in this assay, from the lowest: compounds 3 and 2 (each within the scatter of the next); then compounds 4 and 1 (each within the scatter of the next).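

Read in this assay the exchange of 1-benzothiophen-5-yl for 8-hydroxyquinolin-2-yl gives a 10-fold higher number from compound 3 to compound 4 (1.00 log units; beyond the scatter) and is the first change in the series isolated at a single place. The group on the nitrogen on an aromatic ring therefore matters in this assay: with the rest of compound 3 unchanged, this exchange moves the number beyond the scatter towards weaker inhibition. The step cannot be assigned to the ring exchange or to the hydroxy group alone, and nothing available explains it.

The compounds shown leave open how an unsubstituted quinolin-2-yl, or a quinolin-2-yl carrying a methoxy or an amine in place of the hydroxy group, would read at this place. They also leave open whether the step would be the same on another core substitution or sulfonyl aryl group.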